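Chain extension on the shared core: compound 3 to compound 4

The source may report more compounds than this note shows. Statements on the series, on what has been measured and on what is new or still open speak of the compounds shown alone.

Three compounds have numbers in an assay on isolated protein for inhibition of Aromatase (Homo sapiens), read by fluorescence and colorimetric assay, with a stated time of 30 min; a lower number here means a stronger inhibitor, a higher number a weaker inhibitor. Compound 1 `N#Cc1ccc(C(c2ccc(C#N)cc2)n2cc(COc3ccccc3)nn2)cc1` gives 11000 nM; compound 2 `CCCc1cn(C(c2ccccc2)c2ccccc2)nn1` gives 11000 nM; compound 3 `CCCc1cn(Cc2ccccc2)nn1` gives 12600 nM. The three numbers lie within the scatter of one another, so compound 3 stands level with the other two rather than apart from them. For the measured compounds named here, the single step between compounds differing in one place, a 1.1-fold higher number from compound 2 to compound 3 (0.06 log units; within the scatter), is likewise within the scatter.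

Compound 4 `CCCCCCCCCCc1cn(Cc2ccccc2)nn1` differs from compound 3 by heptyl in place of hydrogen on a saturated chain carbon, three bonds along the chain from an aromatic carbon. Going by the values given here, no measured step touches the length of this chain: the only step in hand, from compound 2 to compound 3, removed a phenyl at a different place and moved nothing beyond the scatter. With nothing in the series pointing in either direction, the expected step in this assay is a 1.1-fold lower number from compound 3 to compound 4 (0.02 log units; within the scatter), none beyond the scatter. Compound 4 is therefore estimated at 12000 nM in this assay, within a range from 3000 nM to 45000 nM that reflects the absence of any chain-length comparison.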

Compound 4, half-maximal inhibitory concentration: 6400 nM
The estimate for compound 4 lay 1.9-fold (0.27 log units) above the measured number, and the stated range covers the measured number.
By their numbers in this assay, from the lowest: compounds 4, 1, 2 and 3 (each within the scatter of the next).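

In this assay, heptyl in place of hydrogen on a saturated chain carbon, three bonds along the chain from an aromatic carbon, gives a 2.0-fold lower number from compound 3 to compound 4 (0.29 log units; within the scatter), so the values of compound 3 and compound 4 stand level. For the compounds shown here, this is the first direct reading on chain length at this position, and it shows that the position accepts heptyl without a change beyond the scatter, whereas the earlier step concerned a phenyl at a different place. No available evidence bears on the size of this step.

On these data alone, whether a longer chain, an amine or a carboxylic acid in place of heptyl at this position would move the number beyond the scatter remains open. Also open, as far as these compounds go, is whether heptyl would give a step of similar size on the core of compound 2.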